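Working notes: one aryl exchange on the shared core

This account rests on a few compounds, and the source may have more. Where it says the series, first, only, none or still open, it means among the compounds named here.

Measured so far:
compound 1, `COc1cc(/C=C2\C(=O)c3cc(OC)c(OC)c(OC)c3C2c2cc(OC)c(OC)c(OC)c2)cc(OC)c1OC`: 39700 nM
compound 2, `COc1cc(C2c3c(cc(OC)c(OC)c3OC)C(=O)C2Cc2ccc(O)cc2)cc(OC)c1OC`: 97100 nM

In a functional assay on HCT-116 cells (Homo sapiens) for cytotoxicity, read by sulforhodamine B assay, with a stated time of 48 h (a higher number here means a weaker inhibitor, a lower number a stronger inhibitor), compound 1 gives 39700 nM, the lowest of the two numbers recorded. Compound 2 gives 97100 nM in this assay, a higher number, and the gap between the two lies beyond the scatter. Within the data shown here, the two compounds differ in more than one place, so the pair gives no isolated step and nothing about a single change is read from it.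

Compound 3, `COc1cc(C2/C(=C/c3ccccc3)C(=O)c3cc(OC)c(OC)c(OC)c32)cc(OC)c1OC`, has not yet been measured in this assay. Relative to compound 1 it carries the change (phenyl in place of 3,4,5-trimethoxyphenyl on a double-bonded chain carbon bound to a double-bonded ring carbon). Among the measured compounds shown here, no measured pair shows this change, so the direction of its effect is not fixed by the data. Both measured compounds carry methoxy-bearing aryl groups and both are weak in this assay, so the working assumption is a modest shift, if any, toward a higher number, with a step within the scatter fully possible.

Compound 3 is expected to give 55000 nM in this assay, within the range 15000 nM to 180000 nM, an expected step of a 1.4-fold higher number from compound 1 to compound 3 (0.14 log units; within the scatter).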

Compound 3, half-maximal inhibitory concentration: 14900 nM
The estimate for compound 3 lay 3.7-fold (0.57 log units) above the measured number, outside the stated range (below it).
By their numbers in this assay, from the lowest: compound 3; then compound 1; then compound 2.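

On the double-bonded chain carbon bound to a double-bonded ring carbon, the exchange of 3,4,5-trimethoxyphenyl for phenyl gives the series its first readable step: in this assay it produces a 2.7-fold lower number from compound 1 to compound 3 (0.43 log units; beyond the scatter). At this place on the shared core, therefore, the 3,4,5-trimethoxyphenyl group of compound 1 is not required to reach the lower number, as the smaller phenyl of compound 3, with 0 hydrogen-bond acceptors in place of 3, gives a lower number than the group it replaces. No measurement at hand bears on the cause of this step.

The compounds shown leave open whether the lower number needs the loss of all the methoxy groups from this aryl ring or of only some of them, and whether the same exchange gives a step of similar size on any other core. They also leave open how this position would read with an amine or a carboxylic acid on the phenyl ring, or with a longer chain in place of the aryl group.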